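A few compounds are considered here, and "the series" means these few. Any claim that something is new, unique, unknown or untested is made for them only; others in the source may bear on it.

Measured compounds:
- Compound 2, `CCCCCCCNC(=O)C(=O)C(CC)NC(=O)C(CC(C)C)NC(=O)OCc1ccccc1`: 67 nM
- Compound 1, `CCOC(=O)C(=O)[C@H](CC)NC(=O)[C@H](CC(C)C)NC(=O)[C@H](CC(C)C)NC(=O)c1ccc2ccccc2c1`: 90 nM

In an assay on isolated protein (Oryctolagus cuniculus) for inhibition of Calpain-2 catalytic subunit (Homo sapiens), at pH 8.0 (on this read-out higher numbers stand for weaker inhibition and lower numbers for stronger inhibition), compound 2 gives 67 nM, and compound 1 gives 90 nM; the two numbers lie within the usual scatter of each other, so neither can be placed ahead of the other on this read-out. Compound 3, `CCC(NC(=O)C(CC(C)C)NC(=O)OCc1ccccc1)C(=O)C(=O)O`, has not yet been measured in this assay. It differs from compound 2 in one place: hydroxy in place of heptylamino on a carbonyl carbon. Going by the values given here, no measured pair shows this change, so its effect is not known from these data. The account expects the number for compound 3 to rise, meaning weaker inhibition, by a step of moderate size in this assay, of about a 4.5-fold higher number from compound 2 to compound 3 (0.65 log units; beyond the scatter). For compound 3 the estimated value in this assay is 300 nM, with a range of 60 nM to 1500 nM, a range wide enough to admit no change beyond the scatter.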

Compound 3, inhibition constant: 22 nM
Beside the measured number, compound 3's estimate is 14-fold (1.13 log units) above it, outside the stated range (below it).
By their numbers in this assay, from the lowest: compound 3; then compounds 2 and 1 (each within the scatter of the next).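

In this assay, hydroxy in place of heptylamino on a carbonyl carbon gives a 3.0-fold lower number from compound 2 to compound 3 (0.48 log units; beyond the scatter), so inhibition at this position does not depend on the heptylcarbamoyl group, and the carboxy form inhibits more strongly. The earlier compounds shown here could not show this, as compound 1 and compound 2 differ in more than one place and no single change had yet been read. No measured evidence accounts for the stronger inhibition.

Going by these compounds, whether a shorter chain on the same nitrogen, such as methylamino or butylamino, would fall nearer to compound 2 or to compound 3 remains open. On these data alone, it also remains open whether ethoxy, the group carried at the matching carbonyl carbon of compound 1, would behave like hydroxy or like heptylamino on the core of compound 3.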